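This account rests on a few compounds, and the source may have more. Where it says the series, first, only, none or still open, it means among the compounds named here.

Measured so far in an assay on HEK293 cells for positive allosteric modulation of metabotropic glutamate receptor 2 (Rattus norvegicus), read by thallium flux, with a stated time of 2.5 min; on this read-out higher numbers stand for larger maximal responses and lower numbers for smaller maximal responses:

compound 1, `COc1cc(C(=O)O)ccc1OCCCCOc1ccc(C(=O)CC(C)C)c(O)c1C`: 85.7%
compound 2, `Cc1c(OCCCCOc2ccc(C(=O)O)cc2)ccc(C(=O)CC2CCCC2)c1O`: 82.6%
compound 3, `CCC(=O)c1ccc(OCCCCOc2cccc(C(=O)O)c2C)c(C)c1O`: 71.3%

Compound 1 gives the highest number of the three. Compound 2 lies within the usual scatter of compound 1, so the two cannot be set in order. Compound 3 lies beyond the scatter and gives a smaller maximal response than compound 1.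

Compound 4, `Cc1c(OCCCCOc2ccc(C(=O)O)cc2F)ccc(C(=O)CC(C)C)c1O`, has not yet been measured. Relative to compound 1 it changes in one place: fluoro in place of methoxy on an aromatic carbon. Going by the values given here, no pair of measured compounds differs in a single place, so no comparable step is known. A small step, not beyond the scatter and perhaps slightly downward, is expected: a number 5.7 percentage points lower from compound 1 to compound 4 (within the scatter). In this assay compound 4 is expected to give about 80%, with a range from 62% to 98%.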

Compound 4, largest response reached (reported as percent of maximum), in percent of the reference or control that the assay uses: 85%
For compound 4 the middle estimate is 5 percentage points below the measured one, and the stated range covers the measured number.
By their numbers in this assay, from the lowest: compound 3; then compounds 2, 4 and 1 (each within the scatter of the next).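

In this assay, going by these compounds alone, the first comparison that changes only one place puts fluoro in place of methoxy on an aromatic carbon, ortho to a large group and meta to a carboxy group, and gives a number 0.7 percentage points lower from compound 1 to compound 4 (within the scatter). The maximal response therefore does not separate the two groups here, even though methoxy has 2 heavy atoms and 1 hydrogen-bond acceptor, while fluoro has 1 heavy atom and none. Nothing measured here accounts for this result.

Going by these compounds, how an amine or a nitrile at this position would fare remains open. So does whether this swap gives the same result with other ketone side chains.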